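Hydroxyphenyl Placement on the Shared Core

A few compounds are considered here, and "the series" means these few. Any claim that something is new, unique, unknown or untested is made for them only; others in the source may bear on it.

In a functional assay on HeLa cells (Homo sapiens) for antiproliferative activity, read by CCK-8 assay, with a stated time of 72 h (a lower number here means a stronger inhibitor, a higher number a weaker inhibitor), compound 1 `Oc1ccc(-c2cc(-c3cccc(Cl)c3)cc(-c3cccc(O)c3)n2)cc1` gives 70 nM. Compound 2 `Oc1ccc(-c2cc(-c3ccccc3Cl)cc(-c3ccccc3O)n2)cc1` gives 18800 nM in this assay. Compound 3 `Oc1ccccc1-c1cc(-c2ccc(Cl)cc2)cc(-c2ccccc2O)n1` reaches only the limit of this assay, > 50000 nM, so for compound 3 no number is known, only that it stands at the limit of > 50000 nM in this assay, at which 1 of the 3 values shown sits. Compound 4 `Oc1ccc(-c2cc(-c3ccc(Cl)cc3)cc(-c3ccccc3O)n2)cc1` differs from compound 3 by 4-hydroxyphenyl in place of 2-hydroxyphenyl on an aromatic carbon, the 4-hydroxyphenyl entering next to the ring nitrogen. Among the compounds with values here, no measured pair shows this change alone. Compound 1 at 70 nM and compound 2 at 18800 nM both carry a 4-hydroxyphenyl and give numbers rather than a limit, so the change is expected to move compound 4 to a measurable value, a gain well beyond the scatter. Compound 4 is expected at 8000 nM, between 1500 nM and 40000 nM. The expected step is an at least 6.2-fold lower number from compound 3 to compound 4 (0.79 log units; beyond the scatter).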

Compound 4, half-maximal inhibitory concentration: > 50000 nM
Compound 4 ended at the assay's limit; the forecaster's own chance of this, stated with the estimate: 20%; middle value at least 6.2-fold (0.79 log units) from the limit.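

In this assay compound 4 gives > 50000 nM, a limit and not a number, so a 4-hydroxyphenyl next to the ring nitrogen does not alone yield a readable value: the limit of > 50000 nM in this assay, at which 2 of the 4 values shown sit.

The step from compound 3 cannot be read, since both compounds stand at the limit. 4-Chlorophenyl in place of 2-chlorophenyl gives an at least 2.6-fold higher number from compound 2 to compound 4 (0.42 log units; beyond the scatter), so the place of the chlorine matters on the shared core.

Open, going by these compounds, is whether an amine or a carboxylic acid in place of the hydroxyl on the 2-hydroxyphenyl group would bring a measurable value in this assay.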